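Cytotoxicity notes: compound 2 toward compound 4

The compounds below may be only part of what the source reports. "The series", "measured", "known", "first", "only" and "open" are said of these compounds alone.

Measured so far in an ADME assay on MT4 cells (Homo sapiens) for cytotoxicity, read by MTT assay, with a stated time of 4 days; a higher number here means that more compound is tolerated, a lower number that less compound is tolerated:
compound 1 `CC1(C)OC(=O)C(=CNc2ccc([N+](=O)[O-])cc2)C(=O)O1`: > 21200 nM
compound 2 `Cc1nc2ccc(NC=C3C(=O)OC(C)(C)OC3=O)cc2s1`: > 317000 nM
compound 3 `CN(C)c1nc2ccc(NC=C3C(=O)OC(C)(C)OC3=O)cc2o1`: > 377000 nM

In this assay compound 1 gives > 21200 nM, a limit of the assay. Compound 2 gives > 317000 nM, likewise a limit. Compound 3 gives > 377000 nM, also a limit. Going by the values given here, compound 2 thus stands, as the other two do, at a limit and not at a number (the limit of > 317000 nM in this assay, at which 1 of the 3 values shown sits), so no step between measured compounds can be sized. Compound 4 `CC1(C)OC(=O)C(=CNc2ccc3ncsc3c2)C(=O)O1` differs from compound 2 by hydrogen in place of methyl on an aromatic carbon. With every value shown at a limit, no step beyond the scatter is expected from compound 2 to compound 4. Compound 4 is therefore expected to give about 300000 nM (range 100000 nM to 900000 nM), most likely again as a limit. That corresponds to an estimated step of an at least 1.0-fold lower number from compound 2 to compound 4 (0.02 log units; that floor lies within the scatter).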

Compound 4, half-maximal cytotoxic concentration: > 39100 nM
Compound 4: no number, only a limit (the forecaster's own chance of this, stated with the estimate: 85%); the middle value is on the limit's open side.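

Compound 2 and compound 4 both stand at limits, so the step from hydrogen in place of methyl on an aromatic carbon cannot be read. The compounds shown leave open whether that change shifts tolerated concentration in this assay at all.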